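Trifluoromethoxy for trifluoromethyl on two different cores

The compounds below may be only part of what the source reports. "The series", "measured", "known", "first", "only" and "open" are said of these compounds alone.

Compound 1 `Oc1cccc2[nH]c(-c3ccc(-c4ccc(-c5ccc(C(F)(F)F)cc5)cc4)cc3)nc12` and compound 2 `Oc1cccc2[nH]c(-c3ccc(-c4ccc(-c5ccc(OC(F)(F)F)cc5)cc4)cc3)nc12` have the same core and differ only at the outermost ring: trifluoromethoxy in place of trifluoromethyl on an aromatic carbon. In a functional assay on Gurav cells (Homo sapiens) for inhibition, read by sulforhodamine B assay (on this read-out higher numbers stand for weaker inhibition of growth and lower numbers for stronger inhibition of growth), compound 1 gives 3190 nM and compound 2 gives 3600 nM; the step is a 1.1-fold higher number from compound 1 to compound 2 (0.05 log units; within the scatter), so the two numbers cannot be told apart here.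

Compound 3 `Cc1ccc2[nH]c(-c3ccc(-c4ccc(-c5ccc(C(F)(F)F)cc5)cc4)cc3)nc2c1` carries a different core; the difference from compound 1 is 5-methyl-1H-benzimidazol-2-yl in place of 4-hydroxy-1H-benzimidazol-2-yl on an aromatic carbon. In this assay compound 3 gives 12000 nM, and the step is a 3.8-fold higher number from compound 1 to compound 3 (0.58 log units; beyond the scatter).

Compound 4 `Cc1ccc2[nH]c(-c3ccc(-c4ccc(-c5ccc(OC(F)(F)F)cc5)cc4)cc3)nc2c1` stands to compound 3 as compound 2 stands to compound 1: trifluoromethoxy in place of trifluoromethyl on an aromatic carbon. The place of the change reads the same in both pairs, so this is the same change made on the core of compound 3. It has been measured once among these compounds, and that step lay within the scatter. Compound 4 is expected to show a step of about a 1.1-fold higher number from compound 3 to compound 4 (0.03 log units; within the scatter) in this assay. Within the data shown here, this expectation rests on the one measured instance, where the same change gave a 1.1-fold higher number from compound 1 to compound 2 (0.05 log units; within the scatter). The estimate for compound 4 in this assay is 13000 nM, with a likely range from 5000 nM to 35000 nM.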

Compound 4, concentration for 50% growth inhibition: 11000 nM
For compound 4 the middle estimate is 1.2-fold (0.07 log units) above the measured one; measured number inside the range.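

Trifluoromethoxy in place of trifluoromethyl on the core of compound 3 gives a 1.1-fold lower number from compound 3 to compound 4 (0.04 log units; within the scatter) in this assay, and this step agrees with the one on the core of compound 1: the same change on two cores in this assay, a 1.1-fold higher number (0.05 log units; within the scatter) from compound 1 to compound 2 and a 1.1-fold lower number (0.04 log units; within the scatter) from compound 3 to compound 4, 1.2-fold (0.09 log units) apart, within the scatter of two such steps. With trifluoromethoxy on the outermost ring, 5-methyl-1H-benzimidazol-2-yl in place of 4-hydroxy-1H-benzimidazol-2-yl gives a 3.1-fold higher number from compound 2 to compound 4 (0.49 log units; beyond the scatter), and this step agrees with the one seen with trifluoromethyl: the same change on two cores in this assay, a 3.8-fold higher number (0.58 log units; beyond the scatter) from compound 1 to compound 3 and a 3.1-fold higher number (0.49 log units; beyond the scatter) from compound 2 to compound 4, 1.2-fold (0.09 log units) apart, within the scatter of two such steps. Within these four compounds, each change therefore carries from one setting to the other with no sign that the two changes interact, but this rests on a single pair of settings in one assay, and a change with no step beyond the scatter shows nothing about how a larger step on the outermost ring would carry over.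

Still open, as far as these compounds go, is how an amine or a carboxylic acid in place of trifluoromethyl would behave on either core. Also open is how a core carrying neither methyl nor hydroxy would compare with the two shown.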